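The source may report more compounds than this note shows. Statements on the series, on what has been measured and on what is new or still open speak of the compounds shown alone.

In a functional assay on the whole organism (strain Swiss) with Mus musculus as the target, in the maximal electroshock model, with a stated time of 1 h, at a dose of 300 mg/kg by the intraperitoneal route (a higher number here means a stronger effect of the compound at the dose given, a lower number a weaker effect), compound 2 `COc1cccc(N2CCN(C(=O)C(C)N3C(=O)CCC3=O)CC2)c1` gives 0%. Compound 2 stands level with compound 3 `CCC(C(=O)N1CCOCC1)N1C(=O)CCC1=O`, which gives 0%, and together they are the lowest of the three numbers; compound 1 `CCC(C(=O)N1CCN(c2ccccc2F)CC1)N1C(=O)CCC1=O`, which gives 50%, lies higher by a margin beyond the scatter. Compound 4 `CC(C(=O)N1CCN(c2ccc(F)cc2)CC1)N1C(=O)CCC1=O` is not yet measured. It differs from compound 2 in one place: 4-fluorophenyl in place of 3-methoxyphenyl on an amine nitrogen in a ring. Among the measured compounds shown here, no measured pair differing in a single place is at hand, and compound 1 differs from compound 2 in more than one place, so the size of this step is uncertain. A modest upward step is expected, a number 25 percentage points higher from compound 2 to compound 4 (beyond the scatter), since the fluorophenyl-bearing compound 1 reached 50%. Compound 4 is therefore estimated at 25%, within 0% to 60%.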

Compound 4, a percentage reported as activity, at one dose (the size of the read-out at that dose, not a potency): 25%
The estimate for compound 4 equals the measured number at the digits printed; the measured number falls inside the stated range.
By their numbers in this assay, from the lowest: compounds 2 and 3 (each within the scatter of the next); then compound 4; then compound 1.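

In this assay, among the compounds shown here, the change to 4-fluorophenyl in place of 3-methoxyphenyl on the ring amine nitrogen gives a number 25 percentage points higher from compound 2 to compound 4 (beyond the scatter) and is the first single-place step available here. It shows that the aryl group at this position alone can move the read-out at the dose given, with the rest of the structure held fixed. Nothing at hand explains this step. Still open, going by these compounds, is whether the step follows the change of substituent or its place on the phenyl ring. An unsubstituted phenyl or a 4-methoxyphenyl on that nitrogen would separate the two.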